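The source may hold more compounds than are shown below. What is called first, only, known or untested is meant among the compounds shown, and "the series" means these compounds.

Measured so far:
Compound 1 `CCN(Cc1ccc(C)s1)C(=O)COc1ccc(C)cc1` gives 178 nM in an assay on HEK293 cells for agonist activity at transient receptor potential cation channel subfamily M member 8 (Homo sapiens), read by fluorescence and calcium flux, with a stated time of 15 min; on this read-out lower numbers stand for an effect already at smaller amounts and higher numbers for an effect only at larger amounts of compound.
Compound 2 `Cc1ccc(OCC(=O)N(Cc2cccs2)c2c[nH]nc2C)cc1` gives 0.4 nM in this assay.
Compound 3 `O=C(COc1ccc2c(c1)CCC2)N(Cc1cccs1)c1ccn[nH]1` gives 0.001 nM in this assay.

Among these three numbers compound 1 stands highest; compound 2 and compound 3 both lie far lower, well beyond the scatter, and both keep a thiophene-bearing methyl group on the amide nitrogen while carrying a different group in place of the ethyl of compound 1. Within the data shown here, no pair of compounds in this set differs in only one place, so no measured step is available to guide the next move.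

Compound 4 `CCN(Cc1c[nH]nn1)C(=O)COc1ccc(C)cc1` differs from compound 1 in one place: 1H-1,2,3-triazol-4-yl in place of 5-methylthiophen-2-yl on a saturated chain carbon bound to an amide-type nitrogen. The two potent compounds, compound 2 and compound 3, give no information on this change, since both retain the thiophene. With nothing in the data to support the new group, the account treats the step as uncertain and leans toward a weakening, with the possibility of a loss beyond the scatter in this assay. Compound 4 is therefore expected to give 900 nM, within 200 nM to 6000 nM, a step estimated as a 5.1-fold higher number from compound 1 to compound 4 (0.70 log units; beyond the scatter).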

Compound 4, half-maximal effective concentration: 31100 nM
Estimate against measurement, compound 4: 35-fold (1.54 log units) below; the measured number lies above the stated range.
By their numbers in this assay, from the lowest: compound 3; then compound 2; then compound 1; then compound 4.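

In this assay, the position on a saturated chain carbon bound to an amide-type nitrogen now has its first measured step: 1H-1,2,3-triazol-4-yl in place of 5-methylthiophen-2-yl gives a 170-fold higher number from compound 1 to compound 4 (2.24 log units; beyond the scatter). This shows that the number at this position depends strongly on which five-membered aromatic ring sits there, and that keeping a ring of this size does not preserve the value. The change replaces a ring with 1 hetero atom and no hydrogen-bond donor by one with 3 hetero atoms and 1 hydrogen-bond donor, and nothing available here explains the step.

Among these compounds, the single step cannot separate the loss of the methyl group from the change of ring. Open too, as far as these compounds go, is how a phenyl ring, a furan-2-yl group or an unsubstituted thiophen-2-yl group would read at this position on the core of compound 1.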